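Working notes: from compound 2 to compound 3

The compounds below may be only part of what the source reports. "The series", "measured", "known", "first", "only" and "open" are said of these compounds alone.

Two compounds of the series have been run in a functional assay on L02 cells (Homo sapiens) for inhibition, read by Griess assay, with stated times of 1 h and 24 h; on this read-out higher numbers stand for weaker inhibition and lower numbers for stronger inhibition. Compound 1 `Brc1ccc(Nc2nc(/C=C/c3ccccc3)nc3ccsc23)cc1` returns only a limit in this assay, > 1000000 nM. Compound 2 `COc1cc(/C=C/c2nc(Nc3ccc(O)cc3)c3sccc3n2)cc(OC)c1OC` likewise returns only a limit in this assay, > 1000000 nM. Going by the values given here, both results sit at the same point, (the limit of > 1000000 nM in this assay, at which 2 of the 2 values shown sit), so no step between measured compounds can be counted and compound 2 stands at that limit alongside compound 1.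

Compound 3 `COc1cc(/C=C/c2nc(NC(C)C)c3sccc3n2)cc(OC)c1OC` is the next member to be run in this assay. It differs from compound 2 in one place: isopropyl in place of 4-hydroxyphenyl on a nitrogen on an aromatic ring. The 4-hydroxyphenyl leaves and isopropyl enters, on a nitrogen on an aromatic ring whose other neighbours are aromatic carbon.

With both known results resting at the limit, the series gives no direction for this change. The expectation is that compound 3 also comes out at the limit, so the estimated step of a number no higher from compound 2 to compound 3 (the limit leaves the size open) is none beyond the scatter. Compound 3 is accordingly estimated at 1000000 nM, with a range from 300000 nM to 3000000 nM, most likely reported as a limit only.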

Compound 3, half-maximal inhibitory concentration: > 1000000 nM
Compound 3: no number, only a limit; the forecaster's own chance of this, stated with the estimate: 85%; the middle value lies on the limit itself.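

No step can be read from compound 2 to compound 3 in this assay, because both compounds return only a limit: the limit of > 1000000 nM in this assay, at which 3 of the 3 values shown sit.

The compounds shown leave open how isopropyl and 4-hydroxyphenyl on that nitrogen compare in this assay, and whether any member of the series gives a numerical half-maximal inhibitory concentration there.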